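Swapping nitro for nitrile on a thiohydantoin antiproliferative

A few compounds are considered here, and "the series" means these few. Any claim that something is new, unique, unknown or untested is made for them only; others in the source may bear on it.

Two open-chain amides and one cyclic thiohydantoin were tested in a functional assay on DU-145 cells (Homo sapiens) for antiproliferative activity, read by propidium iodide staining, with a stated time of 96 h; on this read-out lower numbers stand for stronger inhibition and higher numbers for weaker inhibition. Compound 1 `CC(O)(CSc1cccc(S(F)(F)(F)(F)F)c1)C(=O)Nc1ccc(C#N)c(C(F)(F)F)c1` gives 32700 nM in this assay, and compound 2 `CC(O)(CSc1cccc(S(F)(F)(F)(F)F)c1)C(=O)Nc1ccc([N+](=O)[O-])c(C(F)(F)F)c1` gives 13900 nM. The two differ only by cyano in place of nitro on an aromatic carbon, a change that produced a 2.4-fold higher number from compound 2 to compound 1 (0.37 log units; beyond the scatter). Compound 3 `CC1(C)C(=O)N(c2ccc([N+](=O)[O-])c(C(F)(F)F)c2)C(=S)N1c1cccc(S(F)(F)(F)(F)F)c1` carries the nitro group on a ring-closed core; in this assay compound 3 gives 100000 nM, the highest number of the three. How the core of compound 3 differs from the core of compound 2 is not broken down here.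

Compound 4 `CC1(C)C(=O)N(c2ccc(C#N)c(C(F)(F)F)c2)C(=S)N1c1cccc(S(F)(F)(F)(F)F)c1` is the cyclic partner of compound 1: it differs from compound 3 by cyano in place of nitro on an aromatic carbon, the same change already seen between compound 2 and compound 1, at the same place. If it behaves alike on the cyclic core, the number should drift upward from an already high starting point. The expected step is a 1.5-fold higher number from compound 3 to compound 4 (0.18 log units; within the scatter). Compound 4 is therefore estimated at 150000 nM, within a range from 60000 nM to 400000 nM, and the assay may well report only a limit.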

Compound 4, half-maximal inhibitory concentration: 100000 nM
The estimate for compound 4 lay 1.5-fold (0.18 log units) above the measured number; the range from low to high includes it.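

On the cyclic core in this assay, putting cyano in place of nitro gives no change at the digits printed from compound 3 to compound 4 (within the scatter), whereas the same swap on the open-chain core raised the number modestly. Set side by side, the two steps cannot be told apart: the same change on two cores in this assay, a 2.4-fold higher number (0.37 log units; beyond the scatter) from compound 2 to compound 1 and no change at the digits printed (within the scatter) from compound 3 to compound 4, 2.4-fold (0.37 log units) apart, within the scatter of two such steps. This fits the change carrying over from one core to the other, but it rests on a single pair of compounds per core, so it does not prove that the change acts the same way on both, and it does not explain why compound 3 and compound 4 give such high numbers.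

The compounds shown leave open whether a different group on that same aromatic carbon, such as an amine or a carboxylic acid, would shift the number on either core. They also leave open how the swap from nitro to cyano would behave on a third core.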